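Adding a methoxy to an inactive compound

The source may report more compounds than this note shows. Statements on the series, on what has been measured and on what is new or still open speak of the compounds shown alone.

Measured in a functional assay on HCT-116 cells (Homo sapiens) for cytotoxicity; a lower number here means a stronger inhibitor of growth, a higher number a weaker inhibitor of growth:
Compound 1 `COc1ccc(C23OCC24C(CO)C4Cc2cc(OC)c(OC)cc23)cc1OC`: > 100000 nM
Compound 2 `COc1ccc(C23OCC24C2COC(c5cc(OC)c(OC)cc53)C24)cc1OC`: > 100000 nM

The entry for compound 2, > 100000 nM, is a limit of the assay and not a number. The same holds for compound 1, so neither compound gives a number to work from: the limit of > 100000 nM in this assay, at which 2 of the 2 values shown sit.

Compound 3 `COc1cc2c(cc1OC)C1(c3cc(OC)c(OC)c(OC)c3)OCC13C1COC2C13` differs from compound 2 in one place: a methoxy takes the place of a hydrogen on an aromatic carbon, (methoxy in place of hydrogen on an aromatic carbon). Among the compounds with values here, no measured pair of compounds shows what this change does. With the limit of > 100000 nM in this assay, at which 2 of the 2 values shown sit, little gain is expected in this assay, most likely nothing beyond the scatter, and any change should be towards stronger inhibition. The expected step runs a number no higher from compound 2 to compound 3 (the limit leaves the size open). Compound 3 is estimated at 100000 nM, with a range of 30000 nM to 200000 nM.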

Compound 3, concentration for 50% growth inhibition: 28200 nM
Beside the measured number, compound 3's estimate is 3.5-fold (0.55 log units) above it; the whole stated range lies above it.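

In this assay, putting a methoxy in place of a hydrogen on an aromatic carbon gives an at least 3.5-fold lower number from compound 2 to compound 3 (0.54 log units; beyond the scatter). Within the data shown here, compound 3, at 28200 nM, provides the first true number in this small set, so this position, ortho to a methoxy group and meta to a large group, is one where a single change can give a compound a measured number. The real size of the step remains unknown, since its starting point is only a limit: the limit of > 100000 nM in this assay, at which 2 of the 3 values shown sit.

As far as these compounds go, whether a hydroxyl, an ethoxy or an amine at this position would have a similar effect remains open. Also open, from the compounds shown here alone, is whether the same methoxy would bring a measurable gain on the core of compound 1.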